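The source may report more compounds than this note shows. Statements on the series, on what has been measured and on what is new or still open speak of the compounds shown alone.

Measured so far in a functional assay on SGC-7901 cells (Homo sapiens) for antiproliferative activity, read by MTT assay, with a stated time of 72 h; on this read-out lower numbers stand for stronger inhibition and higher numbers for weaker inhibition: compound 1 `COc1cc(-n2cnc3ccc(-c4cccc(O)c4)cc32)cc(OC)c1OC` gives 53 nM; compound 2 `COc1cc(-n2cnc3ccc(-c4cccc(F)c4)cc32)cc(OC)c1OC` gives 2490 nM. Compound 3 `COc1cc(-n2cnc3ccc(-c4ccc(O)cc4)cc32)cc(OC)c1OC` returns only a limit of this assay, > 10000 nM.

Compound 1 and compound 3 hold the same atoms joined differently, (4-hydroxyphenyl in place of 3-hydroxyphenyl on an aromatic carbon), and the step is an at least 180-fold higher number from compound 1 to compound 3 (2.27 log units; beyond the scatter). The change fluoro in place of hydroxy on an aromatic carbon gives a 47-fold higher number from compound 1 to compound 2 (1.67 log units; beyond the scatter). Between compound 2 and compound 3 the step is an at least 4.0-fold higher number from compound 2 to compound 3 (0.60 log units; beyond the scatter).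

Compound 4 `COc1cc(-n2cnc3ccc(-c4ccc(F)cc4)cc32)cc(OC)c1OC` differs from compound 3 by fluoro in place of hydroxy on an aromatic carbon. This is the same kind of change as from compound 1 to compound 2, but there the fluoro sits meta to a large group, here para to a large group. Compound 3 already sits at the limit of > 10000 nM in this assay, at which 1 of the 3 values shown sits, and the earlier change raised the number, so for compound 4 the expected step is a step that the limit leaves unreadable from compound 3 to compound 4. Compound 4 is estimated at 20000 nM, between 4000 nM and 80000 nM, most likely again only a limit.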

Compound 4, half-maximal inhibitory concentration: 3500 nM
The estimate for compound 4 lay 5.7-fold (0.76 log units) above the measured number; the whole stated range lies above it.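

In this assay, fluoro in place of hydroxy does not carry over from one core to the other, since on the 4-hydroxyphenyl compound it gives an at least 2.8-fold lower number from compound 3 to compound 4 (0.45 log units; beyond the scatter), opposite in direction to the earlier step: the same change on two cores in this assay, a 47-fold higher number (1.67 log units; beyond the scatter) from compound 1 to compound 2 and an at least 2.8-fold lower number (0.45 log units; beyond the scatter) from compound 3 to compound 4, at least 130-fold (2.12 log units) apart, beyond the scatter of two such steps

Compound 3 gives only a limit, > 10000 nM, so that step has a bound and no exact size. 4-Fluorophenyl in place of 3-fluorophenyl gives a 1.4-fold higher number from compound 2 to compound 4 (0.15 log units; within the scatter), and 4-fluorophenyl in place of 3-hydroxyphenyl gives a 66-fold higher number from compound 1 to compound 4 (1.82 log units; beyond the scatter), but these few pairs set no rule for other cores.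

Open, on these data alone, is whether an amine or a methoxy group in place of hydroxy on the 3-hydroxyphenyl ring would keep the value of compound 1, 53 nM.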